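This account rests on a few compounds, and the source may have more. Where it says the series, first, only, none or still open, it means among the compounds named here.

In a functional assay on L1210 cells (Mus musculus) for inhibition (on this read-out lower numbers stand for stronger inhibition and higher numbers for weaker inhibition), compound 1 `C#CCN(Cc1ccc2nc(-n3ccnc3)nc(O)c2c1)c1ccc(C(=O)NC(CCC(=O)O)C(=O)O)cc1` is reported at > 100000 nM, which is a limit of the assay and not a number. Within the data shown here, it is the one compound in the set at that ceiling: the limit of > 100000 nM in this assay, at which 1 of the 3 values shown sits.

Compound 4 `C#CCN(Cc1ccc2nc(SC)nc(O)c2c1)c1ccc(C(=O)NC(CCC(=O)O)C(=O)O)cc1` keeps the rest of compound 1 but carries methylsulfanyl in place of 1H-imidazol-1-yl on an aromatic carbon between two ring nitrogen atoms: methylsulfanyl in place of 1H-imidazol-1-yl on an aromatic carbon.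

Among the measured compounds shown here, no measured step covers this exchange. The only one, a 1.1-fold higher number from compound 2 to compound 3 (0.04 log units; within the scatter), puts methyl in place of hydrogen on a nitrogen, lies within the scatter and leaves that aromatic carbon untouched. The nearest guide is therefore two values from compounds without 1H-imidazol-1-yl: compound 2 `COc1nc(O)c2cc(CNc3ccc(C(=O)NC(CCC(=O)O)C(=O)O)cc3)ccc2n1` gives 6400 nM and compound 3 `COc1nc(O)c2cc(CN(C)c3ccc(C(=O)NC(CCC(=O)O)C(=O)O)cc3)ccc2n1` gives 7000 nM.

A sizeable move toward stronger inhibition is therefore expected, though its full size cannot be fixed from a limit. The expected change is an at least 12-fold lower number from compound 1 to compound 4 (1.09 log units; beyond the scatter). For compound 4 the estimated value is 8000 nM, with an expected range of 1500 nM to 40000 nM.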

Compound 4, half-maximal inhibitory concentration: 13000 nM
Compound 4: middle estimate off by 1.6-fold (0.21 log units), on the low side; the range from low to high includes it.
By their numbers in this assay, from the lowest: compounds 2, 3 and 4 (each within the scatter of the next, the first and the last beyond it). At a limit, above all of these: compound 1.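

In this assay, methylsulfanyl in place of 1H-imidazol-1-yl on the aromatic carbon between two ring nitrogen atoms gives an at least 7.6-fold lower number from compound 1 to compound 4 (0.88 log units; beyond the scatter). Compound 1 stands at > 100000 nM, which is a limit of the assay and not a number. This is the only step shown at this carbon, and it shows that the group there can move inhibition beyond the scatter, though the true size of the step stays open, with only its lower bound known: the limit of > 100000 nM in this assay, at which 1 of the 4 values shown sits.

The compounds shown leave open whether the change reflects methylsulfanyl itself or only the departure of 1H-imidazol-1-yl. A second group on this carbon of the core of compound 1, such as an amine or a longer chain like ethylsulfanyl, would help separate the two.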